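A few compounds are considered here, and "the series" means these few. Any claim that something is new, unique, unknown or untested is made for them only; others in the source may bear on it.

Measured in an ADME assay on MRC5 cells (Homo sapiens) for cytotoxicity, read by neutral red uptake, with a stated time of 24 h; a higher number here means a weaker inhibitor, a lower number a stronger inhibitor:
- compound 1 `CC(=O)Oc1c(C(C)C)cc2c3c1OC(=O)[C@@]31CCCC(C)(C)[C@@H]1CC2`: 290000 nM
- compound 2 `CC(C)C(=O)Oc1c(C(C)C)cc2c3c1OC(=O)[C@@]31CCCC(C)(C)[C@@H]1CC2`: 119000 nM
- compound 3 `CCCCCCCCCCCC(=O)Oc1c(C(C)C)cc2c3c1OC(=O)[C@@]31CCCC(C)(C)[C@@H]1CC2`: > 1000000 nM (a limit)

Compound 3 gives > 1000000 nM, which is a limit of the assay and not a number. Compound 4 `CC(C)c1cc2c3c(c1OC(=O)c1ccccc1)OC(=O)[C@@]31CCCC(C)(C)[C@@H]1CC2` has phenyl in place of undecyl on a carbonyl carbon. All three measured steps change this same carbonyl carbon's group. Introducing undecyl gave an at least 3.4-fold higher number from compound 1 to compound 3 (0.53 log units; beyond the scatter) and an at least 8.4-fold higher number from compound 2 to compound 3 (0.92 log units; beyond the scatter), whereas the step without undecyl was smaller: a 2.4-fold lower number from compound 1 to compound 2 (0.39 log units; beyond the scatter). Within the data shown here, no measured compound carries phenyl, so this comparison is uncertain. With undecyl gone, compound 4 is expected to resemble compound 1 at 290000 nM and compound 2 at 119000 nM. A modest or larger step towards a lower number is therefore expected: an at least 5.0-fold lower number from compound 3 to compound 4 (0.69 log units; beyond the scatter). For compound 4, the estimate is 200000 nM, with an expected range of 70000 nM to 600000 nM.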

Compound 4, half-maximal inhibitory concentration: 512000 nM
The estimate for compound 4 lay 2.6-fold (0.41 log units) below the measured number; measured number inside the range.
By their numbers in this assay, from the lowest: compound 2; then compounds 1 and 4 (each within the scatter of the next). At a limit, above all of these: compound 3.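

Phenyl in place of methyl on this carbonyl carbon gave a 1.8-fold higher number from compound 1 to compound 4 (0.25 log units; within the scatter), so in this assay this aromatic ring cannot be told apart from methyl, while phenyl in place of isopropyl gave a 4.3-fold higher number from compound 2 to compound 4 (0.63 log units; beyond the scatter). Phenyl in place of undecyl gave an at least 1.9-fold lower number from compound 3 to compound 4 (0.29 log units; that floor lies within the scatter). Going by these compounds, compound 3 stands at a limit, so the full size of this step cannot be read: the limit of > 1000000 nM in this assay, at which 1 of the 4 values shown sits. Still open is how a hexyl chain on this carbonyl carbon would read, and whether a phenyl carrying an amine or a carboxylic acid would shift the number.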